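Cyano for Methyl in an Amide and a Carbamate Series

A few compounds are considered here, and "the series" means these few. Any claim that something is new, unique, unknown or untested is made for them only; others in the source may bear on it.

Compound 1, `Cc1cnn(C(=O)NCCCCc2ccccc2)c1`: 550 nM
Compound 2, `N#Cc1cnn(C(=O)NCCCCc2ccccc2)c1`: 42 nM
Compound 3, `Cc1cnn(C(=O)OCCCCc2ccccc2)c1`: only a limit, > 5000 nM

All three were tested in an assay on isolated protein for inhibition of Fatty-acid amide hydrolase 1 (Rattus norvegicus), with a stated time of 3 h; on this read-out higher numbers stand for weaker inhibition and lower numbers for stronger inhibition. Compound 1 and compound 2 share one core and differ in a single place: cyano in place of methyl on an aromatic carbon. This change gives a 13-fold lower number from compound 1 to compound 2 (1.12 log units; beyond the scatter). Compound 3 carries a different core; the difference between the two cores is not broken down here. In this assay compound 3 gives only a limit, > 5000 nM. From the compounds shown here alone, that is the limit of > 5000 nM in this assay, at which 1 of the 3 values shown sits, so the real inhibition constant of compound 3 is unknown beyond the limit.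

Compound 4, `N#Cc1cnn(C(=O)OCCCCc2ccccc2)c1`, has not yet been measured. It differs from compound 3 in exactly the same way that compound 2 differs from compound 1: cyano in place of methyl on an aromatic carbon. The two descriptions of the place match word for word, so the change is the same change on two cores.

If the change acts on the core of compound 3 as it did on the core of compound 1, compound 4 is expected to land at a lower number than compound 3, by a step estimated at an at least 3.3-fold lower number from compound 3 to compound 4 (0.52 log units; beyond the scatter), resting on the step from compound 1 to compound 2 and on the fact that the starting point for compound 3 is only a limit. Compound 4 is therefore estimated at 1500 nM, with a range from 300 nM to 8000 nM.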

Compound 4, inhibition constant: 210 nM
The estimate for compound 4 lay 7.1-fold (0.85 log units) above the measured number; measured number outside the range, below it.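

In this assay, cyano in place of methyl on an aromatic carbon, applied to the core of compound 3, gives an at least 23-fold lower number from compound 3 to compound 4 (1.37 log units; beyond the scatter), so the step points the same way on both cores shown. The two steps can be set side by side: the same change on two cores in this assay, a 13-fold lower number (1.12 log units; beyond the scatter) from compound 1 to compound 2 and an at least 23-fold lower number (1.37 log units; beyond the scatter) from compound 3 to compound 4; the limit leaves it open whether they differ. Compound 3 gives a limit and not a number, so these two pairs show that the direction of the change carried over from one core to the other, but they do not show that its size carried over: the limit of > 5000 nM in this assay, at which 1 of the 4 values shown sits.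

With only two matched pairs, the compounds shown leave open whether the same direction would hold on further cores, such as one with a longer chain in place of the chain shared here. They also leave open how other groups on that aromatic carbon, such as chloro, trifluoromethyl or a carboxylic acid, would compare with cyano and methyl on either core.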